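This account rests on a few compounds, and the source may have more. Where it says the series, first, only, none or still open, it means among the compounds named here.

Measured so far:
- compound 1, `C[C@H](Oc1cccc(Cl)c1Cl)C(=O)Nc1ccc2oc(C3=CC=NCC3=O)nc2c1`: in an assay on isolated protein for inhibition of GMP reductase 2 (Homo sapiens), read by spectrophotometry (on this read-out lower numbers stand for stronger inhibition and higher numbers for weaker inhibition), compound 1 gives > 5000 nM, which is a limit of the assay rather than a number.
- compound 2, `C[C@H](Oc1cccc(Cl)c1Cl)C(=O)Nc1ccc2oc(-c3ccc(OC(F)(F)F)cc3)nc2c1`: in this assay compound 2 gives > 5000 nM, again a limit of the assay rather than a number.

Among the measured compounds shown here, compound 2 therefore stands nowhere definite on the scale: only a limit is known for it, and the one other value shown is a limit as well, so both sit at the limit of > 5000 nM in this assay, at which 2 of the 2 values shown sit. For the measured compounds named here, the single measured step, a step that the two limits leave unreadable from compound 1 to compound 2, is unreadable for the same reason and offers no size to lean on.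

Compound 3, `C[C@H](Oc1cccc(Cl)c1Cl)C(=O)Nc1ccc2oc(-c3ccc(F)cc3)nc2c1`, differs from compound 2 only in that (fluoro in place of trifluoromethoxy on an aromatic carbon). Going by the values given here, no measured step concerns this change, and the two values shown give no direction for it. Among the compounds with values here, the expectation for a step that the limit leaves unreadable from compound 2 to compound 3 is therefore no step that can be read beyond the scatter, with the most likely outcome that compound 3 also returns a limit. For compound 3 the estimate in this assay is 8000 nM, within 2500 nM to 30000 nM.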

Compound 3, inhibition constant: > 5000 nM
Compound 3 ended at the assay's limit; the forecaster's own chance of this, stated with the estimate: 75%; the middle value does not contradict the limit.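

Among the compounds shown here, no step between compound 1, compound 2 and compound 3 can be read, because all three stop at the same value, which is a limit of the assay and not a number: the limit of > 5000 nM in this assay, at which 3 of the 3 values shown sit. The compounds shown leave open how strong the inhibition by each one really is, and whether changing the group on the shared core alters it at all.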